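The source may report more compounds than this note shows. Statements on the series, on what has been measured and on what is new or still open speak of the compounds shown alone.

Measured so far in a functional assay on HeLa cells (Homo sapiens) for inhibition, read by CCK-8 assay, with a stated time of 72 h, tested at 2 uM; on this read-out lower numbers stand for less inhibition of growth and higher numbers for more inhibition of growth at the one concentration tested:

Compound 1 `COc1ccc(SCc2ccc(C(=O)Nc3ccccc3N)cc2)cc1`: 35%
Compound 2 `Nc1ccccc1NC(=O)c1ccc(CSc2ccc(Br)cc2)cc1`: 18.8%

Compound 2 stands lowest of these two, and the gap to compound 1 lies beyond the usual scatter. The next compound, compound 3 `CC(C)(C)c1ccc(SCc2ccc(C(=O)Nc3ccccc3N)cc2)cc1`, keeps the shared core and changes a single group: tert-butyl in place of bromo on an aromatic carbon. In words, this is tert-butyl in place of bromo on an aromatic carbon, and the carbon lies in a six-membered aromatic ring of carbon only, para to a large group.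

Within the data shown here, only one measured step bears on this change: a number 16.2 percentage points lower from compound 1 to compound 2 (beyond the scatter). That modest step, bromo in place of methoxy, shows that the group at this place can move the read-out. It says nothing directly about tert-butyl, which has not yet been tested here. Among the measured compounds shown here, with so little to go on, the best guess is a landing between the two known numbers, so a step smaller than that one is expected, pointing slightly upward. The expected change in this assay is a number 6.2 percentage points higher from compound 2 to compound 3 (within the scatter), which may not clear the scatter. Compound 3 is estimated at 25%, with an expected range from 10% to 45%.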

Compound 3, percent growth inhibition at one concentration: 9.73%
Estimate against measurement, compound 3: 15.3 percentage points above; the measured number lies below the stated range.
By their numbers in this assay, from the lowest: compounds 3 and 2 (each within the scatter of the next); then compound 1.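

In this assay putting tert-butyl in place of bromo gives a number 9.1 percentage points lower from compound 2 to compound 3 (within the scatter) and so does not separate these two groups, even though tert-butyl brings 4 heavy atoms where bromo has 1. Set against methoxy, the same group gives a number 25.3 percentage points lower from compound 1 to compound 3 (beyond the scatter) and this shows that the gap first seen with bromo is not peculiar to that one group: of the three groups tested at this place on the ring, only methoxy stands apart, with the highest growth inhibition at the single concentration used. No separate measurement is available to explain why methoxy differs from the other two groups.

From the compounds shown here alone, it remains open whether the higher number belongs to methoxy alone or would also appear with a hydroxyl group, an ethoxy group or an amine at the same place. A plain hydrogen at this place, or a carboxylic acid, would show whether bromo and tert-butyl sit at a low level shared by many groups, and a full concentration series would show how far these single-concentration gaps hold.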